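The source may hold more compounds than are shown below. What is called first, only, known or untested is meant among the compounds shown, and "the series" means these compounds.

Two compounds here share the same core and differ only in what sits on the six-membered aromatic ring of carbon only attached to it. Compound 1 `COc1cccc(-c2ccc3ccc(C)nc3c2)c1` carries a methoxy group there, and in a functional assay on CHO cells for inhibition of metabotropic glutamate receptor 5 (Rattus norvegicus), read by FLIPR and calcium flux (a higher number here means a weaker inhibitor, a lower number a stronger inhibitor), compound 1 gives 860 nM. Compound 2 `Cc1ccc2ccc(-c3cc(Cl)cc(C#N)c3)cc2n1` carries a chloro group and a cyano group instead, and in this assay compound 2 gives 1.4 nM, the lowest of the two numbers shown and far from compound 1, a gap well beyond the scatter. Compound 3 `Cc1ccc2ccc(-c3cc(C#N)cc(OC(F)(F)F)c3)cc2n1` takes one further step: trifluoromethoxy in place of chloro on an aromatic carbon. For the measured compounds named here, no measured pair shows this particular exchange, so its effect is not known from these data. The step expected in this assay is modest, a 2.9-fold higher number from compound 2 to compound 3 (0.46 log units; beyond the scatter), a slight weakening at most, close to the scatter. Compound 3 is therefore estimated at 4 nM, with a likely range from 1.2 nM to 15 nM.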

Compound 3, half-maximal inhibitory concentration: 75 nM
The estimate for compound 3 lay 19-fold (1.27 log units) below the measured number; measured number above the stated range.
By their numbers in this assay, from the lowest: compound 2; then compound 3; then compound 1.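

With the cyano group unchanged, trifluoromethoxy in place of chloro gives a 54-fold higher number from compound 2 to compound 3 (1.73 log units; beyond the scatter) in this assay, so this position on the ring is sensitive to which group sits there. For the compounds shown here, this is the first exchange here made at a single place, since compound 1 and compound 2 differ by more than one group on that ring, and it shows that chloro alone can matter a great deal while the cyano group stays. Nothing measured here accounts for the size of this step. Going by these compounds, it remains open whether fluoro, methyl or an amine at this place would keep the number close to that of compound 2. Also open, on these data alone, is whether the same exchange would give a similar step with a group other than cyano on the ring.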